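Replacing naphthalen-1-yl with ethyl on the sulfur chain

This account rests on a few compounds, and the source may have more. Where it says the series, first, only, none or still open, it means among the compounds named here.

- compound 1 `Cc1cc(Nc2cc(-c3ccccc3)[nH]n2)n2nc(SCc3cccc(Br)c3)nc2n1`: 5140 nM
- compound 2 `Cc1cc(Nc2cc(-c3ccccc3)[nH]n2)n2nc(SCc3cccc4ccccc34)nc2n1`: 7560 nM

In a functional assay on MCF7 cells (Homo sapiens) for inhibition, read by MTT assay, with a stated time of 72 h (a lower number here means a stronger inhibitor, a higher number a weaker inhibitor), compound 2 cannot be told apart from compound 1. Going by the values given here, the only measured step (a 1.5-fold higher number from compound 1 to compound 2 (0.17 log units; within the scatter)) is small, and it swapped one aromatic group for another. Compound 3 `CCCSc1nc2nc(C)cc(Nc3cc(-c4ccccc4)[nH]n3)n2n1` instead has ethyl in place of naphthalen-1-yl on a saturated chain carbon bound to a sulfur. Among the compounds with values here, no measured compound yet shows what losing those aromatic rings does. A slight move towards a higher number is expected, not clearly beyond the scatter (a 1.2-fold higher number from compound 2 to compound 3 (0.08 log units; within the scatter)). The estimated value in this assay for compound 3 is 9000 nM (3500 nM to 25000 nM).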

Compound 3, half-maximal inhibitory concentration: > 50000 nM
Compound 3: a limit, no number; the forecaster's own chance of this, stated with the estimate: 15%; at least 5.5-fold (0.74 log units) between middle value and limit.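

In this assay compound 3 gives only a limit, not a number: the limit of > 50000 nM in this assay, at which 1 of the 3 values shown sits. Swapping one aromatic group for another had revealed little at this place, but losing the aromatic rings clearly counts: ethyl in place of naphthalen-1-yl gives an at least 6.6-fold higher number from compound 2 to compound 3 (0.82 log units; beyond the scatter), and ethyl in place of 3-bromophenyl gives an at least 9.7-fold higher number from compound 1 to compound 3 (0.98 log units; beyond the scatter). Across these compounds, then, an aromatic group on a saturated chain carbon bound to a sulfur goes with the lower numbers.

On these data alone, whether the aromatic ring itself matters, or only the number of carbons, stays open. A longer chain such as hexyl, or a saturated ring such as cyclohexyl, would separate the two.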